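A few compounds are considered here, and "the series" means these few. Any claim that something is new, unique, unknown or untested is made for them only; others in the source may bear on it.

Measured compounds:
- compound 1, `CCCCC#Cc1cc([C@@H]2O[C@H](CO)[C@@H](O)[C@H]2O)n2ncnc(N)c12`: 1000 nM
- compound 2, `Nc1ncnn2c([C@@H]3O[C@H](CO)[C@@H](O)[C@H]3O)cc(C#Cc3cccs3)c12`: 32000 nM
- compound 3, `Nc1ncnn2c([C@@H]3O[C@H](CO)[C@@H](O)[C@H]3O)cc(C#Cc3ccccc3)c12`: 37700 nM

These three compounds were tested in a functional assay on CAPAN-1 cells (Homo sapiens) for antiproliferative activity, with a stated time of 72 h; a lower number here means a stronger inhibitor, a higher number a weaker inhibitor. Compound 3 gives the highest number of the three: its value and that of compound 2 sit within the scatter of each other, as shown by a 1.2-fold higher number from compound 2 to compound 3 (0.07 log units; within the scatter), while the gap to compound 1 is large, a 38-fold higher number from compound 1 to compound 3 (1.58 log units; beyond the scatter). The step of a 32-fold higher number from compound 1 to compound 2 (1.51 log units; beyond the scatter) points the same way, so replacing butyl by an aromatic ring on the triple-bonded carbon costs much activity in both cases.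

Compound 4, `Nc1ncnn2c([C@@H]3O[C@H](CO)[C@@H](O)[C@H]3O)cc(-c3ccc(Cl)cc3)c12`, has not yet been measured. It differs from compound 3 by 4-chlorophenyl in place of 2-phenylethynyl on an aromatic carbon. Among the compounds with values here, none of the measured steps covers this kind of change: the two aryl-ethynyl compounds differ from each other only within the scatter, and no compound with an aromatic ring bound directly to the core has a value. Within the data shown here, the only guidance is that both aryl-ethynyl compounds are weak; whether removing the triple bond and adding chlorine helps or hurts cannot be read from the data. The expectation is therefore a step of modest size at most, a 1.9-fold lower number from compound 3 to compound 4 (0.28 log units; within the scatter), with wide uncertainty. Compound 4 is estimated at 20000 nM, in a range from 4000 nM to 100000 nM.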

Compound 4, half-maximal inhibitory concentration: 56700 nM
Compound 4: middle estimate off by 2.8-fold (0.45 log units), on the low side; the range from low to high includes it.
By their numbers in this assay, from the lowest: compound 1; then compounds 2, 3 and 4 (each within the scatter of the next).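

In this assay, within the data shown here, compound 4 shows for the first time an aromatic ring bound directly to the core at this position, and swapping the aryl-ethynyl groups for 4-chlorophenyl leaves the number within the scatter (a 1.5-fold higher number from compound 3 to compound 4 (0.18 log units; within the scatter)) and (a 1.8-fold higher number from compound 2 to compound 4 (0.25 log units; within the scatter)). Among these compounds with an aromatic ring, then, the presence of the triple bond makes no readable difference, although the loss of the triple bond and the gain of chlorine cannot be separated in this single change. The large gap to the hex-1-yn-1-yl group persists (a 57-fold higher number from compound 1 to compound 4 (1.75 log units; beyond the scatter)), so compound 1 alone stands apart from the other three.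

No measured finding offers an explanation for these steps. Going by these compounds, it remains open whether a butyl chain bound directly to the core, without the triple bond, or an unsubstituted phenyl would match compound 1 or join the other three.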